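Ester Tail Change and the Expected Potency of Compound 3

The compounds below may be only part of what the source reports. "The series", "measured", "known", "first", "only" and "open" are said of these compounds alone.

Among the compounds with values here, compound 2 `CCOc1ccc(-c2cccc(C(=O)OCCOC)c2)cc1` is the only member of this small set with a number in an assay on COS-7 cells for inhibition of patatin-like phospholipase domain-containing protein 2 (Mus musculus) (on this read-out lower numbers stand for stronger inhibition and higher numbers for weaker inhibition), where compound 2 gives 70000 nM. Compound 1 `CCCCCCOC(=O)c1cccc(-c2ccc(OCC)cc2)c1` is reported in this assay only as a limit, > 200000 nM. Within the data shown here, the one measured step, an at least 2.8-fold lower number from compound 1 to compound 2 (0.45 log units; beyond the scatter), is therefore at least modest and rests on (the limit of > 200000 nM in this assay, at which 1 of the 2 values shown sits). Compound 3 `CCOc1ccc(-c2cccc(C(=O)OCC(F)(F)F)c2)cc1` differs from compound 2 by trifluoromethyl in place of methoxymethyl on a saturated chain carbon bound to an oxygen next to a carbonyl group. This change sits on the same ester tail that the measured step altered, yet it is not the same change, so that step offers only a rough scale for what to expect. Compound 3 is expected to stay close to compound 2, with a 1.1-fold higher number from compound 2 to compound 3 (0.06 log units; within the scatter) expected to remain within the scatter in either direction. The estimate for compound 3 is 80000 nM, within a range from 25000 nM to 250000 nM.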

Compound 3, half-maximal inhibitory concentration: 120000 nM
Estimate against measurement, compound 3: 1.5-fold (0.18 log units) below; the measured number falls inside the stated range.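

Replacing methoxymethyl with trifluoromethyl on a saturated chain carbon bound to an oxygen next to a carbonyl group gives a 1.7-fold higher number from compound 2 to compound 3 (0.23 log units; within the scatter) in this assay, so this read-out does not separate the 2-methoxyethyl and 2,2,2-trifluoroethyl esters. The group that enters has no hydrogen-bond acceptor and the group that leaves has one, yet the two compounds remain within the scatter of each other. The comparison with the hexyl ester gives an at least 1.6-fold lower number from compound 1 to compound 3 (0.22 log units; that floor lies within the scatter), and it stays a floor that cannot be read as a firm difference because compound 1 is reported only as a limit: the limit of > 200000 nM in this assay, at which 1 of the 3 values shown sits.

The compounds shown leave open how a primary amine or a carboxylic acid at this ester tail would read. They also leave open whether a plain ethyl ester would match compound 2, and whether any change to the shared core would matter more than the tail.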